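The compounds below may be only part of what the source reports. "The series", "measured", "known", "first", "only" and "open" are said of these compounds alone.

Measured in a functional assay on NB1 cells (Homo sapiens) for antiproliferative activity, with a stated time of 72 h; a higher number here means a weaker inhibitor, a lower number a stronger inhibitor:
- compound 1 `O=C(CCN(Cc1ccc(C(=O)NO)cc1)C(=O)c1ccccc1)NCc1ccccc1`: 6660 nM
- compound 2 `COc1cc(OC)cc(C(=O)N(CCC(=O)NCc2ccccc2)Cc2ccc(C(=O)NO)cc2)c1`: 13300 nM
- compound 3 `Cc1ccc(NC(=O)CCN(Cc2ccc(C(=O)NO)cc2)C(=O)c2ccccc2)cc1`: 1480 nM

Compound 3 has the lowest number of the three, at 1480 nM. Compound 4 `Cc1ccc(NC(=O)CCN(Cc2ccc(C(=O)NO)cc2)C(=O)c2ccc(N(C)C)cc2)cc1` differs from it by dimethylamino in place of hydrogen on an aromatic carbon, para to a large group: dimethylamino in place of hydrogen on an aromatic carbon. The same change reads as benzoyl to (4-(dimethylamino)phenyl)carbonyl.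

Among the measured compounds shown here, one measured step touches this ring: a 2.0-fold higher number from compound 1 to compound 2 (0.30 log units; within the scatter), with 3,5-dimethoxyphenyl in place of phenyl on a carbonyl carbon. That step stays within the scatter. The other step, a 4.5-fold lower number from compound 1 to compound 3 (0.65 log units; beyond the scatter), with 4-methylphenyl in place of benzyl on an amide-type nitrogen, goes beyond the scatter but concerns a different place, so it bears on the starting level and not on the new change. For the measured compounds named here, the series holds no measured example with dimethylamino, and the only precedent on this ring carries different groups, so the range stays wide.

No step beyond the scatter is therefore expected in this assay, with only a slight lean towards a higher number. The estimated step is a 1.3-fold higher number from compound 3 to compound 4 (0.11 log units; within the scatter). For compound 4 the expected value is 1900 nM, with an estimated range of 700 nM to 5000 nM.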

Compound 4, half-maximal inhibitory concentration: 660 nM
Compound 4: the middle estimate sits 2.9-fold (0.46 log units) above what was measured; the whole stated range lies above it.
By their numbers in this assay, from the lowest: compound 4; then compound 3; then compounds 1 and 2 (each within the scatter of the next).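

In this assay, the ring carbon para to a large group responds to substitution: dimethylamino in place of hydrogen gives a 2.2-fold lower number from compound 3 to compound 4 (0.35 log units; beyond the scatter) and is a modest step beyond the scatter. Among the compounds shown here, the only earlier change on this ring, a 2.0-fold higher number from compound 1 to compound 2 (0.30 log units; within the scatter), stayed within the scatter, involved 3,5-dimethoxyphenyl in place of phenyl, and had benzyl on the amide-type nitrogen rather than 4-methylphenyl, so this is the first step on the ring that can be read as a real difference. No measurement of any property of these compounds accompanies the step, and the data offer no explanation for it.

On these data alone, whether the lower number is specific to dimethylamino remains open, since a primary amine, methoxy or a carboxylic acid at the same place could give a different step. Also unresolved is whether the step would hold with benzyl on the amide-type nitrogen, as in compound 1, and how dimethylamino would read at another carbon of the ring.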